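From 3-chlorophenyl to 2-fluorophenyl on an amide-type nitrogen

This account rests on a few compounds, and the source may have more. Where it says the series, first, only, none or still open, it means among the compounds named here.

In a functional assay on HepG2 cells (Homo sapiens) for antiproliferative activity, read by MTT assay, with a stated time of 48 h (a lower number here means a stronger inhibitor, a higher number a weaker inhibitor), compound 1 `O=C(Nc1ccc(Cl)cc1)Nc1cccc(CNc2nccnc2Cl)c1` gives 8350 nM and compound 3 `O=C(Nc1cccc(Cl)c1)Nc1cccc(CNc2nccnc2Cl)c1` gives 9140 nM. These two cannot be told apart, as the swap of 4-chlorophenyl for 3-chlorophenyl gives a 1.1-fold higher number from compound 1 to compound 3 (0.04 log units; within the scatter). Compound 2 `CN(C)c1ccc(NC(=O)Nc2cccc(CNc3nccnc3Cl)c2)cc1` reads > 40000 nM, which is a limit of the assay and not a number. Replacing chloro with dimethylamino gives an at least 4.7-fold higher number from compound 1 to compound 2 (0.68 log units; beyond the scatter), and the change back to a chlorophenyl group gives an at least 4.3-fold lower number from compound 2 to compound 3 (0.64 log units; beyond the scatter). Compound 3 therefore stands with compound 1, clear of compound 2.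

Compound 4 `O=C(Nc1cccc(CNc2nccnc2Cl)c1)Nc1ccccc1F` brings the next change: 2-fluorophenyl in place of 3-chlorophenyl on an amide-type nitrogen. It places 2-fluorophenyl in place of 3-chlorophenyl on an amide-type nitrogen. For the measured compounds named here, the closest precedent is the halogen-bearing pair of compound 1 and compound 3, with a 1.1-fold higher number from compound 1 to compound 3 (0.04 log units; within the scatter), whereas the larger steps involve dimethylamino, which is absent here. Going by the values given here, no measured compound carries a 2-fluorophenyl group, so the range stays wide. No step beyond the scatter is expected, and the estimate is a 1.2-fold higher number from compound 3 to compound 4 (0.08 log units; within the scatter). Compound 4 is expected at 11000 nM, within an estimated range of 5000 nM to 28000 nM.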

Compound 4, half-maximal inhibitory concentration: 10500 nM
Compound 4: the middle estimate sits 1.0-fold (0.02 log units) above what was measured; low and high end bracket the measured number.
By their numbers in this assay, from the lowest: compounds 1, 3 and 4 (each within the scatter of the next). At a limit, above all of these: compound 2.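

In this assay, the 2-fluorophenyl group on the amide-type nitrogen cannot be told apart from either chlorophenyl group: the swap gives a 1.1-fold higher number from compound 3 to compound 4 (0.06 log units; within the scatter), and the swap from 4-chlorophenyl gives a 1.3-fold higher number from compound 1 to compound 4 (0.10 log units; within the scatter). Fluorine thus joins chlorine in this series, with compounds 1, 3 and 4 forming one group within the scatter, while the 4-(dimethylamino)phenyl group stays apart, at an at least 3.8-fold lower number from compound 2 to compound 4 (0.58 log units; beyond the scatter). Compound 2 remains a limit of the assay and not a number: the limit of > 40000 nM in this assay, at which 1 of the 4 values shown sits.

From the compounds shown here alone, it remains open whether any group on this nitrogen could give a number clearly lower than those of compounds 1, 3 and 4, such as a phenyl ring carrying trifluoromethyl or methoxy. Going by these compounds, it is also open how an unsubstituted phenyl ring or a phenyl ring carrying a carboxylic acid would read here.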